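Pyrrolidinyl for propylsulfanyl on a sodium/hydrogen exchanger inhibitor

This account rests on a few compounds, and the source may have more. Where it says the series, first, only, none or still open, it means among the compounds named here.

Measured compounds:
Compound 1, `Cc1ccc(-c2ccc(C(=O)N=C(N)N)cc2S(C)(=O)=O)cc1`: 100 nM
Compound 2, `CCCSc1cc(C)c(C(=O)N=C(N)N)cc1S(C)(=O)=O`: 6.8 nM
Compound 3, `CCc1cc(OC)c(S(C)(=O)=O)cc1C(=O)N=C(N)N`: 30 nM

Three acylguanidines carrying a methylsulfonyl group have been measured in a functional assay for inhibition of sodium/hydrogen exchanger (Oryctolagus cuniculus); on this read-out lower numbers stand for stronger inhibition and higher numbers for weaker inhibition. Compound 2 gives the lowest of the three numbers, 6.8 nM. Its nearest neighbour is compound 3, whose value of 30 nM lies beyond the usual scatter above it, and compound 1 stands furthest away at 100 nM, also beyond the scatter. Going by the values given here, since no two of the three differ in a single place, no measured step can be drawn from them, and compound 2 is simply the strongest inhibitor among those measured.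

Compound 4, `Cc1cc(N2CCCC2)c(S(C)(=O)=O)cc1C(=O)N=C(N)N`, is derived from compound 2 by one change: pyrrolidin-1-yl in place of propylsulfanyl on an aromatic carbon. The propylsulfanyl group of compound 2 gives way to a five-membered ring with one nitrogen, at the position ortho to the methylsulfonyl group and para to the group of six heavy atoms.

Among the compounds with values here, no measured pair shows what such a swap does in this assay, so the expectation rests on compound 2 alone. The number for compound 4 is estimated at 12 nM, within a range of 4 nM to 40 nM. This expected step from compound 2 to compound 4, a 1.8-fold higher number from compound 2 to compound 4 (0.25 log units; within the scatter), is a modest weakening that may still fall inside the scatter.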

Compound 4, half-maximal inhibitory concentration: 11 nM
The estimate for compound 4 lay 1.1-fold (0.04 log units) above the measured number; measured number inside the range.
By their numbers in this assay, from the lowest: compounds 2 and 4 (each within the scatter of the next); then compound 3; then compound 1.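

In this assay, replacing propylsulfanyl with pyrrolidin-1-yl gives a 1.6-fold higher number from compound 2 to compound 4 (0.21 log units; within the scatter), so on this read-out the two compounds cannot be told apart. Going by these compounds alone, this is the first single-place step, and it shows that the aromatic carbon ortho to the methylsulfonyl group and para to the group of 6 heavy atoms can carry either an open chain attached through sulfur or a five-membered non-aromatic ring attached through nitrogen without a change that exceeds the scatter, something the earlier compounds, which differ in more than one place, could not show. Nothing available speaks to what lies behind this result.

The compounds shown do not say whether this tolerance extends to other groups at the same carbon, such as a dimethylamino group, a piperidin-1-yl ring, a morpholin-4-yl ring or a carboxylic acid. They also leave open whether a longer sulfur-linked chain, or an oxygen-linked chain such as propoxy, would stay as close to compound 2 on this read-out.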